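This account rests on a few compounds, and the source may have more. Where it says the series, first, only, none or still open, it means among the compounds named here.

Of the compounds shown here, two of the study have been measured in a functional assay on HepG2 cells (Homo sapiens) for antiproliferative activity, read by MTT assay, with a stated time of 48 h; a higher number here means a weaker inhibitor, a lower number a stronger inhibitor. Compound 1 `N#CC1=C(N)Oc2c(c3nc4ccccc4nc3c3ccccc23)C12C(=O)N(Cc1cnnn1-c1cccc(S(N)(=O)=O)c1)c1ccccc12` gives 21500 nM in this assay. Compound 2 `N#CC1=C(N)Oc2c(N)cc3nc4ccccc4nc3c2C12C(=O)N(Cc1cnnn1-c1cccc(Br)c1)c1ccccc12` is known only as a limit of this assay, reported as > 50000 nM; this is the limit of > 50000 nM in this assay, at which 1 of the 2 values shown sits. Between compound 1 and compound 2 no single-place step is described, so their two values show only that compound 1 falls at a number and compound 2 at a limit.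

Compound 3 `N#CC1=C(N)Oc2c(N)cc3nc4ccccc4nc3c2C12C(=O)N(Cc1cnnn1-c1ccc([N+](=O)[O-])cc1)c1ccccc12` has not been measured. It differs from compound 2 in one place: 4-nitrophenyl in place of 3-bromophenyl on an aromatic nitrogen. For the measured compounds named here, no measured step of this kind is available, so the expectation for compound 3 rests on compound 2 standing at its limit. The change from compound 2 is expected to give a step of an at least 1.1-fold lower number from compound 2 to compound 3 (0.04 log units; that floor lies within the scatter) in this assay, which is to say none beyond the usual scatter. Compound 3 is therefore estimated at 45000 nM in this assay, with a range from 15000 nM to 150000 nM, and it is expected that this assay may again report only a limit for compound 3.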

Compound 3, half-maximal inhibitory concentration: > 50000 nM
Compound 3: no number, only a limit; the forecaster's own chance of this, stated with the estimate: 60%; at least 1.1-fold (0.04 log units) between middle value and limit.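

In this assay, compound 2 and compound 3 are both known only as a limit, so the step from one to the other cannot be read: the limit of > 50000 nM in this assay, at which 2 of the 3 values shown sit.

The compounds shown leave open what number either compound would give, and whether 4-nitrophenyl in place of 3-bromophenyl on the aromatic nitrogen shifts that number at all.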